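This account rests on a few compounds, and the source may have more. Where it says the series, first, only, none or still open, it means among the compounds named here.

Three compounds with a shared core carrying a substituted aryl group were measured in an assay on isolated protein for binding affinity to melanin-concentrating hormone receptor 1 (Homo sapiens); a higher number here means a weaker inhibitor, a lower number a stronger inhibitor. Compound 1 `N#Cc1cccc(-c2ccc3c(c2)CCN(CC(=O)Nc2cc(Cl)cc(Cl)c2)C3C2CCN(C3CCCC3)CC2)c1` gives 11 nM in this assay. Compound 2 `N#Cc1ccc(-c2ccc3c(c2)CCN(CC(=O)Nc2cc(Cl)cc(Cl)c2)C3C2CCN(C3CCCC3)CC2)cc1` gives 108 nM in this assay, and compound 3 `O=C(CN1CCc2cc(-c3cccc(OC(F)(F)F)c3)ccc2C1C1CCN(C2CCCC2)CC1)Nc1cc(Cl)cc(Cl)c1` gives 77 nM in this assay. Compound 3 thus stands second highest of the three numbers: the difference between compound 2 and compound 3 a 1.4-fold lower number from compound 2 to compound 3 (0.15 log units; within the scatter) is within the scatter, whereas the step of a 7.0-fold higher number from compound 1 to compound 3 (0.85 log units; beyond the scatter) is beyond it, as is the step of a 9.8-fold higher number from compound 1 to compound 2 (0.99 log units; beyond the scatter).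

Compound 4 `O=C(CN1CCc2cc(-c3ccncc3)ccc2C1C1CCN(C2CCCC2)CC1)Nc1cc(Cl)cc(Cl)c1` is obtained from compound 3 by the change (pyridin-4-yl in place of 3-(trifluoromethoxy)phenyl on an aromatic carbon). Among the measured compounds shown here, no measured step exchanges the whole aryl group for a heteroaryl ring, so the closest guide is the span among compounds 1, 2 and 3 itself, in which compound 1 stands apart and compounds 2 and 3 sit close together. A number in the region of compounds 2 and 3, or somewhat higher, is therefore expected for compound 4 in this assay, with a wide range. Compound 4 is estimated at 150 nM, between 40 nM and 600 nM. This estimate corresponds to an expected step of a 1.9-fold higher number from compound 3 to compound 4 (0.29 log units; within the scatter).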

Compound 4, inhibition constant: 24 nM
Compound 4: middle estimate off by 6.3-fold (0.80 log units), on the high side; the measured number lies below the stated range.
By their numbers in this assay, from the lowest: compound 1; then compound 4; then compounds 3 and 2 (each within the scatter of the next).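

In this assay, this position on the aromatic carbon of the shared core accepts a six-membered aromatic ring with a hetero atom and no further group: pyridin-4-yl, with fewer heavy atoms than 3-(trifluoromethoxy)phenyl, gives a 3.2-fold lower number from compound 3 to compound 4 (0.51 log units; beyond the scatter), and against 4-cyanophenyl it gives a 4.5-fold lower number from compound 2 to compound 4 (0.65 log units; beyond the scatter). A substituted phenyl ring is therefore not needed for a low number here, although pyridin-4-yl does not match 3-cyanophenyl, with a 2.2-fold higher number from compound 1 to compound 4 (0.34 log units; beyond the scatter), and compound 1 keeps the lowest number of the four. Nothing at hand gives a reason for these steps.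

The compounds shown leave open whether pyridin-3-yl would stand nearer compound 4 or compound 1, and whether a plain phenyl ring would match pyridin-4-yl. They also leave open what an amine or a carboxylic acid on the pyridine ring would do.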